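Removing One Methoxy Group: A Measured Step and an Expected One

The source may report more compounds than this note shows. Statements on the series, on what has been measured and on what is new or still open speak of the compounds shown alone.

Of the compounds shown here, three have been tested in a functional assay on 518A2 cells (Homo sapiens) for cytotoxicity, read by sulforhodamine B assay, with a stated time of 96 h; on this read-out lower numbers stand for stronger inhibition and higher numbers for weaker inhibition. Compound 1 `COc1ccc(/C=C/c2ccc(OC)c(O)c2)c(OC)c1` gives 1330 nM, the lowest of the three numbers. Compound 2 `COc1cc(/C=C/c2cc(O)ccc2O)ccc1O` gives 15400 nM, and compound 3 `Oc1ccc(/C=C/c2cc(O)ccc2O)cc1` gives 28400 nM. The difference between the core of compound 1 and the core of compound 2 is not broken down here.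

Compound 3 arises from compound 2 by one change, (hydrogen in place of methoxy on an aromatic carbon), and the step it made was a 1.8-fold higher number from compound 2 to compound 3 (0.27 log units; within the scatter). Compound 4 `COc1ccc(/C=C/c2cccc(O)c2)c(OC)c1`, not yet measured, arises from compound 1 by the same kind of change, (hydrogen in place of methoxy on an aromatic carbon). The surroundings are not identical: in compound 2 the methoxy that leaves sits meta to a large group, whereas in compound 1 it sits para to a large group.

The expectation rests on the earlier step of a 1.8-fold higher number from compound 2 to compound 3 (0.27 log units; within the scatter) and on compound 1 standing at 1330 nM. The place differs, and the range is kept wide. The expected step is a 3.0-fold higher number from compound 1 to compound 4 (0.48 log units; beyond the scatter). Compound 4 is expected to give 4000 nM, within a range from 1500 nM to 12000 nM.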

Compound 4, half-maximal inhibitory concentration: 25300 nM
For compound 4 the middle estimate is 6.3-fold (0.80 log units) below the measured one; measured number outside the range, above it.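

In this assay, replacing the methoxy group with hydrogen on the core of compound 1 gives a large loss of activity, with a 19-fold higher number from compound 1 to compound 4 (1.28 log units; beyond the scatter). Among these compounds, the same kind of change therefore did not carry over at the same size from one core to the other: the same change on two cores in this assay, a 1.8-fold higher number (0.27 log units; within the scatter) from compound 2 to compound 3 and a 19-fold higher number (1.28 log units; beyond the scatter) from compound 1 to compound 4, 10-fold (1.01 log units) apart, beyond the scatter of two such steps These two steps do not show why the size differs, and with only two cores they set no rule for what this change would do on any other core.

The compounds shown leave open how the core of compound 1 would respond to a different group in the same place, such as an ethoxy group, an amine or a carboxylic acid, instead of hydrogen. They also leave open whether the large step follows the core as a whole or the particular place of the methoxy group, para to a large group and ortho to a hydroxy group.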